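Fluoro to Ethyl on Compound 2: Expected Potency

A few compounds are considered here, and "the series" means these few. Any claim that something is new, unique, unknown or untested is made for them only; others in the source may bear on it.

Measured compounds in a functional assay, with a stated time of 30 min; on this read-out lower numbers stand for stronger inhibition and higher numbers for weaker inhibition:
compound 1 `CCCCc1oc2ccc(/N=C/c3ccc(Cl)cc3)cc2c1C(=O)c1ccc(OC)cc1` gives 75.9 ug/mL
compound 2 `CCCCc1oc2ccc(/N=C/c3ccc(F)cc3)cc2c1C(=O)c1ccc(OC)cc1` gives 100 ug/mL
compound 3 `CCCCc1oc2ccc(/N=C/c3ccc([N+](=O)[O-])cc3)cc2c1C(=O)c1ccc(OC)cc1` gives 53.1 ug/mL

Compound 2 has the highest of these three numbers, yet its gap to compound 1, a 1.3-fold higher number from compound 1 to compound 2 (0.12 log units; within the scatter), and to compound 3, a 1.9-fold lower number from compound 2 to compound 3 (0.27 log units; within the scatter), both stay within the scatter, so the three are indistinguishable. Compound 4 `CCCCc1oc2ccc(/N=C/c3ccc(CC)cc3)cc2c1C(=O)c1ccc(OC)cc1` differs from compound 2 by ethyl in place of fluoro on an aromatic carbon. Within the data shown here, none of the measured steps involves ethyl, but the replacements of the same substituent, a 1.4-fold lower number from compound 1 to compound 3 (0.16 log units; within the scatter) and a 1.9-fold lower number from compound 2 to compound 3 (0.27 log units; within the scatter), all fell within the scatter. The step of a 1.4-fold lower number from compound 2 to compound 4 (0.15 log units; within the scatter) is therefore expected to be small. Compound 4 is estimated at 70 ug/mL, with a range from 35 ug/mL to 140 ug/mL.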

Compound 4, half-maximal inhibitory concentration: 3.69 ug/mL
Beside the measured number, compound 4's estimate is 19-fold (1.28 log units) above it, and the stated range ends above it.
By their numbers in this assay, from the lowest: compound 4; then compounds 3, 1 and 2 (each within the scatter of the next).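

Ethyl shows that this place on the ring is not indifferent to its substituent, as fluoro, chloro and nitro alone had suggested: the number falls sharply against fluoro (a 27-fold lower number from compound 2 to compound 4 (1.43 log units; beyond the scatter)), and also against chloro (a 21-fold lower number from compound 1 to compound 4 (1.31 log units; beyond the scatter)) and nitro (a 14-fold lower number from compound 3 to compound 4 (1.16 log units; beyond the scatter)). Compound 4 therefore stands clearly apart from the other three compounds. Nothing available accounts for a change of this size.

From the compounds shown here alone, whether the effect is specific to ethyl remains open. Methyl, propyl or a longer chain would show whether it depends on chain length, and an amine would show whether a group not made only of carbon and hydrogen can match it.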